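Pyridine-carboxamide series, metabotropic glutamate receptor 5 binding

The compounds below may be only part of what the source reports. "The series", "measured", "known", "first", "only" and "open" are said of these compounds alone.

Measured in an assay on membranes from brain for displacement of a labelled ligand from metabotropic glutamate receptor 5 (Rattus norvegicus); a lower number here means a stronger inhibitor, a higher number a weaker inhibitor:
compound 1 `Cc1cccc(NC(=O)c2nccn2C)n1`, 3070 nM
compound 2 `Cc1cccc(NC(=O)c2cc(-c3cccc(C#N)c3)ccn2)n1`, 320 nM
compound 3 `Cc1cccc(NC(=O)c2cc(-c3cccc4ccccc34)ccn2)n1`, 250 nM

Compound 2 stands second highest of the three numbers. Compound 3 lies lower by a margin within the usual scatter, so no order between the two is claimed; compound 1, which carries no pendant ring on the core, lies higher by a margin well beyond it.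

Compound 4 `Cc1cccc(NC(=O)c2cc(-c3ncccn3)ccn2)n1` differs from compound 2 by pyrimidin-2-yl in place of 3-cyanophenyl on an aromatic carbon. Among the compounds with values here, no measured pair covers this change, so the expectation rests on compound 2 and compound 3 alone, both of which carry a pendant ring and sit far below compound 1. A smaller, nitrogen-rich ring enters; a moderate rise in the number, possibly not beyond the scatter, is expected, and a 2.0-fold higher number from compound 2 to compound 4 (0.31 log units; beyond the scatter) is the step this estimate means. Compound 4 is estimated at 650 nM, with a range from 200 nM to 2200 nM.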

Compound 4, inhibition constant: 2480 nM
The estimate for compound 4 lay 3.8-fold (0.58 log units) below the measured number; the whole stated range lies below it.
By their numbers in this assay, from the lowest: compounds 3 and 2 (each within the scatter of the next); then compounds 4 and 1 (each within the scatter of the next).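

In this assay, pyrimidin-2-yl in place of 3-cyanophenyl gives a 7.8-fold higher number from compound 2 to compound 4 (0.89 log units; beyond the scatter) at this position, opposite the ring nitrogen. A pendant ring here is therefore not enough to keep the number near that of compound 2; the identity of the ring counts. Nothing shown accounts for this step.

Open, from the compounds shown here alone, is whether the rise follows the ring nitrogens that enter or the nitrile that leaves: plain phenyl or a pyridinyl ring at the same place would separate these. Also open, going by these compounds, is how an amine or a carboxylic acid on the pendant ring would fare.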